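The compounds below may be only part of what the source reports. "The series", "measured", "known", "first", "only" and "open" are said of these compounds alone.

Compound 1 `O=C(Nc1nccn2cc(-c3ccccc3)nc12)c1ccccc1`: 18%
Compound 2 `Cc1ccc(C(=O)Nc2nccn3cc(-c4ccccc4)nc23)cc1`: 26%

In an assay on cells for displacement of a labelled ligand from adenosine receptor A1 (Homo sapiens), read by scintillation counting, with a stated time of 120 min, tested at 1 uM (on this read-out lower numbers stand for less inhibition and higher numbers for more inhibition at the one concentration tested (going by the name of the read-out)), compound 2 and compound 1 lie within the scatter of each other: the step of a number 8 percentage points higher from compound 1 to compound 2 (within the scatter) does not separate them. Compound 3 `Cc1ccc(C(=O)Nc2nc(-c3ccccc3)cn3cc(-c4ccccc4)nc23)cc1` differs from compound 2 by phenyl in place of hydrogen on an aromatic carbon. Among the measured compounds shown here, no measured step concerns a phenyl entering at this place; the single step, a number 8 percentage points higher from compound 1 to compound 2 (within the scatter), is a methyl change and within the scatter, so it gives no direction for this one. Compound 3 is therefore expected near compound 2, as an estimated 30%, ranging from 5% to 65%, an expected step of a number 4 percentage points higher from compound 2 to compound 3 (within the scatter).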

Compound 3, a percentage reported as inhibition, at one concentration (the size of the read-out at that concentration, not a potency): 1%
For compound 3 the middle estimate is 29 percentage points above the measured one; the whole stated range lies above it.
By their numbers in this assay, from the lowest: compound 3; then compounds 1 and 2 (each within the scatter of the next).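

In this assay, phenyl on this aromatic carbon next to the ring nitrogen gives a number 25 percentage points lower from compound 2 to compound 3 (beyond the scatter), so this position on the ring with two nitrogens is not indifferent to substitution. This is the first step among these compounds that lies beyond the scatter, unlike the methyl change on the benzoyl ring, a number 8 percentage points higher from compound 1 to compound 2 (within the scatter). Nothing available bears on why the number falls.

Going by these compounds, whether the fall belongs to phenyl in particular or to any group on this carbon remains open, since an amine or a methoxy group there could read differently. Also open, on these data alone, is whether the same change would lower the number without the methyl group of compound 2.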